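Dimethylamino in place of the oxolane on the shared core

This account rests on a few compounds, and the source may have more. Where it says the series, first, only, none or still open, it means among the compounds named here.

Compound 3 `COc1cc(-c2cnn3cc(OC)c([C@@H]4COC(C)(C)C4)nc23)ccn1` gives 30% in an ADME assay on microsomes from liver (Rattus norvegicus) for metabolic stability, with a stated time of 60 min, tested at 1 uM; a higher number here means that more of the compound is left, a lower number that less of the compound is left. Among the three compounds measured, compound 3 stands lowest; compound 1 `COc1cc(-c2cnn3cc(OC)c(C4CCOC4)nc23)ccn1` with 34% lies nearest, and the two numbers are within the scatter of each other, while compound 2 `CNc1nc2c(-c3ccnc(OC)c3)cnn2cc1OC` with 74% lies furthest away, beyond the scatter.

Compound 4 `COc1cc(-c2cnn3cc(OC)c(N(C)C)nc23)ccn1` is not yet measured. Going from compound 3 to compound 4, the change is a group of 3 heavy atoms (2 carbon, 1 nitrogen; no ring) in place of a group of 7 heavy atoms (6 carbon, 1 oxygen; one five-membered non-aromatic ring with 1 hetero atom), on an aromatic carbon. Going by the values given here, two measured steps bear on this. From compound 2 to compound 3 the ring group entered in place of a small amino group, and a number 44 percentage points lower from compound 2 to compound 3 (beyond the scatter) was seen. The step of a number 40 percentage points higher from compound 1 to compound 2 (beyond the scatter) likewise shows a large rise when methylamino replaced oxolan-3-yl on the same aromatic carbon. The move to compound 4 runs in the same sense as both, a small amino group replacing the ring, so a large step upward is expected in this assay.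

On that basis compound 4 is expected to give about 65%, between 45% and 85%, which is an estimated a number 35 percentage points higher from compound 3 to compound 4 (beyond the scatter).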

Compound 4, percent of the compound remaining: 3%
Estimate against measurement, compound 4: 62 percentage points above; measured number outside the range, below it.
By their numbers in this assay, from the lowest: compound 4; then compounds 3 and 1 (each within the scatter of the next); then compound 2.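

Going by these compounds alone, at this aromatic carbon, next to the ring nitrogen, the earlier compounds could be read as showing that any small amino group in place of the ring gives a high number in this assay; the new result rules that reading out. A single methyl in place of hydrogen on the nitrogen gives a number 71 percentage points lower from compound 2 to compound 4 (beyond the scatter) and accounts for the largest step in the series, so the high number belongs to methylamino and does not carry over to dimethylamino. Dimethylamino also stands under both ring-bearing compounds, with a number 31 percentage points lower from compound 1 to compound 4 (beyond the scatter) and a number 27 percentage points lower from compound 3 to compound 4 (beyond the scatter), so removing the ring does not by itself raise the number, and no information at hand accounts for this reversal.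

The compounds shown leave open how an unsubstituted amine, an ethylamino group or a ring amine such as morpholine would read on this same carbon, and so whether methylamino is an isolated high point or part of a wider set of amines. They also leave open whether the gap between methylamino and dimethylamino would persist with a different group in place of the methoxy on the shared core.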